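Swapping pyridin-2-yl for 2-methyl-1,3-thiazol-4-yl on the amide

The source may report more compounds than this note shows. Statements on the series, on what has been measured and on what is new or still open speak of the compounds shown alone.

Three compounds that share one core and differ only in the group attached to the amide carbonyl have been tested in a functional assay on MCF7 cells (Homo sapiens) for antiproliferative activity, read by MTT assay, with a stated time of 72 h; a higher number here means a weaker inhibitor, a lower number a stronger inhibitor. Compound 1 `O=C(Nc1ccc(Cl)c(-c2nnc3c(Cl)cccn23)c1)c1ccc(C(F)(F)F)cc1Cl` gives 81600 nM in this assay. Compound 2 `O=C(Nc1ccc(Cl)c(-c2nnc3c(Cl)cccn23)c1)c1ccc(F)cc1Cl` reaches only the limit of this assay, > 100000 nM, and not a number. Compound 3 `O=C(Nc1ccc(Cl)c(-c2nnc3c(Cl)cccn23)c1)c1ccccn1` gives 96400 nM in this assay; its number and that of compound 1 lie within the usual scatter of each other, so no order between them can be read. The remaining value, that of compound 2, is a limit (the limit of > 100000 nM in this assay, at which 1 of the 3 values shown sits).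

The measured steps are small: an at least 1.2-fold higher number from compound 1 to compound 2 (0.08 log units; that floor lies within the scatter) and an at least 1.0-fold lower number from compound 2 to compound 3 (0.01 log units; that floor lies within the scatter), both with floors inside the scatter. The second of these, an exchange of the whole group on the carbonyl carbon, changed nothing beyond the scatter.

Compound 4 `Cc1nc(C(=O)Nc2ccc(Cl)c(-c3nnc4c(Cl)cccn34)c2)cs1` is the next compound, not yet measured in this assay. It differs from compound 3 in one place: 2-methyl-1,3-thiazol-4-yl in place of pyridin-2-yl on a carbonyl carbon. Since the earlier exchange on the same carbonyl carbon, from compound 2 to compound 3, stayed within the scatter, a step of about a 1.0-fold lower number from compound 3 to compound 4 (0.01 log units; within the scatter) is expected, in no clear direction. Compound 4 is therefore expected to give roughly 95000 nM in this assay, with a likely range from 40000 nM to 250000 nM, and a fair chance that only a limit is reported.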

Compound 4, half-maximal inhibitory concentration: > 100000 nM
Compound 4: no number, only a limit; the forecaster's own chance of this, stated with the estimate: 45%; middle value at least 1.0-fold (0.02 log units) away from the limit.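

In this assay compound 4 gives > 100000 nM, which is a limit of the assay and not a number. As far as these compounds go, putting the five-membered, sulfur-containing 2-methyl-1,3-thiazol-4-yl ring in place of the six-membered pyridin-2-yl ring on the carbonyl carbon gives an at least 1.0-fold higher number from compound 3 to compound 4 (0.01 log units; that floor lies within the scatter), so this new kind of ring brings no readable gain in strength at this position, and its true size of effect remains unknown beyond that floor. The step between the two compounds that gave only limits cannot be read, and limits now make up a large share of the set, which restricts what can be compared at this position: the limit of > 100000 nM in this assay, at which 2 of the 4 values shown sit.

All the groups shown on this carbonyl carbon are aromatic rings, so it remains open whether a non-aromatic group, such as a piperidine ring or a short chain ending in an amine or a carboxylic acid, would give a clearly lower number. Also open, from the compounds shown here alone, is how far the true values of compound 2 and compound 4 lie beyond the limit, and whether they differ from each other at all.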